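A Pyridine Swap on a Spirocyclic Orexin Antagonist

The source may hold more compounds than are shown below. What is called first, only, known or untested is meant among the compounds shown, and "the series" means these compounds.

Measured so far:
compound 1, `O=C(c1nc(C(F)(F)F)ccc1-c1ncccn1)N1CC2(CC2)C[C@H]1CNc1ccc(C(F)(F)F)cn1`, gives 5 in a functional assay on HEK293 cells for antagonist activity at Orexin receptor type 2 (Homo sapiens), read by FLIPR and calcium flux; on this read-out higher numbers stand for higher potency (the scale is a negative logarithm) and lower numbers for lower potency
compound 2, `Cc1ccc(-n2nccn2)c(C(=O)N2CCC3(CC3)C[C@H]2CNc2cccc(C)n2)c1`, gives < 5 in this assay
compound 3, `N#Cc1ccc(-c2ncccn2)c(C(=O)N2CC3(CC3)C[C@H]2CNc2ccc(C(F)(F)F)cn2)c1`, gives 8.1 in this assay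

Compound 2 yields no number in this assay: its value is a limit of the assay, (the limit of < 5 in this assay, at which 1 of the 3 values shown sits). Compound 4, `Cc1ccc(-n2nccn2)c(C(=O)N2CCC3(CC3)C[C@H]2CNc2ccc(Cl)cn2)c1`, differs from compound 2 in one place: 5-chloropyridin-2-yl in place of 6-methylpyridin-2-yl on an amine nitrogen. Going by the values given here, no measured pair shows this exact change, so its size is open. Compounds 1 and 3 carry a different pyridine; compound 1 reaches 5, and compound 3 reaches 8.1. The expected step of a number at least 1.00 log units higher from compound 2 to compound 4 (beyond the scatter) is upward but uncertain, as compound 2 rests on a limit. Compound 4 is expected to reach about 6, within 5 to 7.2.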

Compound 4, negative logarithm of the antagonist equilibrium constant: < 5
Compound 4: no number, only a limit; the forecaster's own chance of this, stated with the estimate: 25%; middle value at least 1.00 log units from the limit.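

Compound 2 and compound 4 both rest on a limit rather than a number, so no step between them can be read: the limit of < 5 in this assay, at which 2 of the 4 values shown sit.

As far as these compounds go, whether 5-chloropyridin-2-yl in place of 6-methylpyridin-2-yl changes potency at all remains open.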